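Removing the Carboxy Group from a Glutamate Receptor Modulator

The source may report more compounds than this note shows. Statements on the series, on what has been measured and on what is new or still open speak of the compounds shown alone.

Measured compounds:
compound 1, `Cc1c(OC[C@@H](C)COc2ccc(C(=O)O)cc2Cl)ccc(C(=O)CC(C)(C)C)c1O`, gives 477 nM
compound 2, `Cc1cc(OC[C@H](C)COc2ccc(C(=O)CC(C)(C)C)c(O)c2C)ccc1C(=O)O`, gives 305 nM
compound 3, `Cc1c(OC[C@@H](C)COc2ccc(C(=O)O)c(F)c2)ccc(C(=O)CC(C)(C)C)c1O`, gives 261 nM

In an assay for positive allosteric modulation of metabotropic glutamate receptor 2 (Rattus norvegicus) (a higher number here means that more compound is needed for the effect, a lower number that less compound is needed), compound 3 has the lowest of the three numbers, but only narrowly: the closest step is a 1.2-fold lower number from compound 2 to compound 3 (0.07 log units; within the scatter) and the widest is a 1.8-fold lower number from compound 1 to compound 3 (0.26 log units; within the scatter), both within the scatter, so compound 3 cannot be set apart from the other two.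

Compound 4, `COc1cccc(OC[C@H](C)COc2ccc(C(=O)CC(C)(C)C)c(O)c2C)c1`, differs from compound 3 in one place: 3-methoxyphenyl in place of 4-carboxy-3-fluorophenyl on an oxygen on a saturated carbon. The three measured steps, a 1.6-fold lower number from compound 1 to compound 2 (0.19 log units; within the scatter), a 1.8-fold lower number from compound 1 to compound 3 (0.26 log units; within the scatter) and a 1.2-fold lower number from compound 2 to compound 3 (0.07 log units; within the scatter), each swap one carboxy-bearing ring for another and all stay within the scatter. Within the data shown here, none of them removes the carboxy group, so none bears directly on this change; the data give no measured precedent for it. With the acid gone and only a methoxy left on the ring, a higher number is expected, though with wide uncertainty. Compound 4 is thus expected to show a 5.7-fold higher number from compound 3 to compound 4 (0.76 log units; beyond the scatter). The estimate for compound 4 in this assay is 1500 nM, ranging from 300 nM to 8000 nM.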

Compound 4, half-maximal effective concentration: "not active" (no number reported)
Nothing numeric was reported for compound 4, and the estimate cannot be compared.
By their numbers in this assay, from the lowest: compounds 3, 2 and 1 (each within the scatter of the next).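

In this assay, among these compounds, compound 4 is reported as not active, without a number, so no step from compound 3 to compound 4 can be read. Nothing shown accounts for this result. The compounds shown leave open whether any ring without a carboxy group can give a measurable number on this core.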